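This account rests on a few compounds, and the source may have more. Where it says the series, first, only, none or still open, it means among the compounds named here.

In an ADME assay on HFF cells (Homo sapiens) for cytotoxicity, read by MTT assay, with a stated time of 72 h (on this read-out lower numbers stand for stronger inhibition and higher numbers for weaker inhibition), compound 1, `O=C1O[C@H]([C@@H](O)Cn2cc(-c3cccc(O)c3)nn2)C(OCc2ccccc2)=C1OCc1ccccc1`, gives 39000 nM, compound 2, `CC(C)(C)OC(=O)N1CCN(C(=S)SCc2cn(C[C@H](O)[C@H]3OC(=O)C(OCc4ccccc4)=C3OCc3ccccc3)nn2)CC1`, gives 60 nM, and compound 3, `O=C1O[C@H]([C@@H](O)Cn2cc(CNS(=O)(=O)c3ccc(F)cc3)nn2)C(OCc2ccccc2)=C1OCc1ccccc1`, gives 30 nM. Compound 3 therefore stands level with compound 2, inside the scatter, and far from compound 1.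

Next is compound 4, `O=C1O[C@H]([C@@H](O)Cn2cc(CCCCl)nn2)C(OCc2ccccc2)=C1OCc1ccccc1`, which carries 2-chloroethyl in place of ((4-fluorophenyl)sulfonyl)amino on a saturated chain carbon bound to an aromatic carbon.

Within the data shown here, only one measured step bears on this change: a 1300-fold lower number from compound 1 to compound 3 (3.11 log units; beyond the scatter). It is large and shows that this assay can respond strongly to the group on that aromatic carbon. Among the measured compounds shown here, no measured compound carries a chlorinated chain, so its direction cannot be transferred directly. With compound 1 at 39000 nM, the measured span leaves far more room upward than downward from compound 3.

The expected change is a 17-fold higher number from compound 3 to compound 4 (1.22 log units; beyond the scatter), toward a higher number, beyond the scatter but well short of that large step. For compound 4 the estimated value is 500 nM, with an expected range from 30 nM to 15000 nM.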

Compound 4, half-maximal inhibitory concentration: 27100 nM
For compound 4 the middle estimate is 54-fold (1.73 log units) below the measured one; the measured number lies above the stated range.
By their numbers in this assay, from the lowest: compounds 3 and 2 (each within the scatter of the next); then compounds 4 and 1 (each within the scatter of the next).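

In this assay, a 900-fold higher number from compound 3 to compound 4 (2.96 log units; beyond the scatter) shows that the low number of compound 3 does not carry over to every group at this place, a saturated chain carbon bound to an aromatic carbon: with 2-chloroethyl in place of ((4-fluorophenyl)sulfonyl)amino, it is lost. The second step, a 1.4-fold lower number from compound 1 to compound 4 (0.16 log units; within the scatter), places 3-chloropropyl and 3-hydroxyphenyl on an aromatic carbon level in this assay, even though only the latter has a ring, so among these three compounds only the (((4-fluorophenyl)sulfonyl)amino)methyl group stands apart from the others. Nothing available explains either step.

Going by these compounds, it remains open whether the low number goes with the 4-fluorophenyl ring or with the sulfonyl and amino link. A methylsulfonylamino group, a phenylsulfonylamino group without fluorine or a plain amine at this place would help separate these.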